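This account rests on a few compounds, and the source may have more. Where it says the series, first, only, none or still open, it means among the compounds named here.

Results so far in a functional assay on MCF7 cells (Homo sapiens) for inhibition, read by CCK-8 assay, with a stated time of 48 h; a higher number here means a weaker inhibitor, a lower number a stronger inhibitor
Compound 1 `COc1cc(-c2ccnc3cc(-c4ccc(C)cc4)nn23)cc(OC)c1OC` gives 47 nM
Compound 2 `COc1cc(-c2ccnc3cc(-c4ccc(C(C)=O)cc4)nn23)cc(OC)c1OC` gives 5230 nM

Compound 2 holds the higher of the two numbers, which makes it the weaker inhibitor of the pair. Among the measured compounds shown here, its only measured neighbour is compound 1, and the step between them, a 110-fold higher number from compound 1 to compound 2 (2.05 log units; beyond the scatter), comes with acetyl in place of methyl on an aromatic carbon.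

Compound 3 `COc1ccc(-c2cc3nccc(-c4cc(OC)c(OC)c(OC)c4)n3n2)cc1F` has not yet been measured. Its difference from compound 2 is 3-fluoro-4-methoxyphenyl in place of 4-acetylphenyl on an aromatic carbon. For the measured compounds named here, no measured step covers the entering group, so the only guide is the large step above. The acetyl group leaves, and compound 1, which lacks it, stands at 47 nM in this assay. A lower number is therefore expected, recovering much but probably not all of that gap. The expected change is a 26-fold lower number from compound 2 to compound 3 (1.42 log units; beyond the scatter), large and beyond the scatter, though one step is thin evidence. The estimate for compound 3 is 200 nM, with an expected range from 30 nM to 1500 nM.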

Compound 3, half-maximal inhibitory concentration: 183 nM
Beside the measured number, compound 3's estimate is 1.1-fold (0.04 log units) above it; the measured number falls inside the stated range.
By their numbers in this assay, from the lowest: compound 1; then compound 3; then compound 2.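

In this assay, the change of 4-acetylphenyl to 3-fluoro-4-methoxyphenyl on this aromatic carbon of the five-membered ring gives a 29-fold lower number from compound 2 to compound 3 (1.46 log units; beyond the scatter), so the weak result for compound 2 does not extend to every substituted phenyl at this place, and the two groups differ this much although they match in heavy-atom and hydrogen-bond acceptor counts. Recovery is incomplete, since 3-fluoro-4-methoxyphenyl in place of 4-methylphenyl gives a 3.9-fold higher number from compound 1 to compound 3 (0.59 log units; beyond the scatter), a modest step that leaves the 4-methylphenyl of compound 1 with the lowest number of the three, with both its steps beyond the scatter. No measurement shown here gives any reason for the size of either step.

The fluorine and the methoxy group enter together in compound 3, so the three compounds cannot show what each contributes alone, and a phenyl carrying only one of them would be needed to separate the two. They also leave open how an amine, a carboxylic acid or a longer alkyl chain on the phenyl ring would behave at this place, and whether the order seen here holds beyond this single cell line.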